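Ring-nitrogen aminomethyl variation: compound 2 to compound 3

The compounds below may be only part of what the source reports. "The series", "measured", "known", "first", "only" and "open" are said of these compounds alone.

Measured so far:
compound 1, `O=C1C(=O)N(CN(c2ccccc2)c2ccccc2)c2ccccc21`, gives 21500 nM in a functional assay on MDA-MB-468 cells (Homo sapiens) for cytotoxicity, read by sulforhodamine B assay, with a stated time of 48 h; a lower number here means a stronger inhibitor of growth, a higher number a weaker inhibitor of growth
compound 2, `CN(C)CN1C(=O)C(=O)c2c(Br)cccc21`, gives 49000 nM in this assay

Among the compounds with values here, compound 2 stands at the highest of the two numbers in this assay; its only neighbour, compound 1, gives 21500 nM, and that gap lies beyond the usual scatter. Within the data shown here, the two compounds differ in more than one place, so their pair gives no isolated step to lean on.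

Compound 3, `CCN(CC)CN1C(=O)C(=O)c2c(Br)cccc21`, differs from compound 2 by diethylamino in place of dimethylamino on a saturated chain carbon bound to an amide-type nitrogen in a ring. Among the measured compounds shown here, no measured pair covers this exchange. The change is small, keeps the amine and its acceptor, and is expected to give no step beyond the scatter in this assay in either direction.

Compound 3 is therefore expected to give 40000 nM, with a range of 15000 nM to 110000 nM. The step of a 1.2-fold lower number from compound 2 to compound 3 (0.09 log units; within the scatter) that this estimate implies is expected to stay within the scatter.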

Compound 3, concentration for 50% growth inhibition: 11700 nM
For compound 3 the middle estimate is 3.4-fold (0.53 log units) above the measured one; measured number below the stated range.
By their numbers in this assay, from the lowest: compounds 3 and 1 (each within the scatter of the next); then compound 2.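

In this assay, within the data shown here, diethylamino in place of dimethylamino on a saturated chain carbon bound to an amide-type nitrogen in a ring gives a 4.2-fold lower number from compound 2 to compound 3 (0.62 log units; beyond the scatter) as the first isolated step. With the shared core held fixed, the alkyl groups on this amine are enough on their own to move the number beyond the scatter, so this position is not silent. No available measurement explains why this exchange lowers the number.

From the compounds shown here alone, a single pair sets no trend, so it remains open whether the step continues with dipropylamino or changes with a ring amine such as piperidine or morpholine. Going by these compounds, whether the same exchange gives a similar step on the core of compound 1 also remains open.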